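From an Ethyl Group to an Acrylamide-Type Group

The source may hold more compounds than are shown below. What is called first, only, known or untested is meant among the compounds shown, and "the series" means these compounds.

Compound 2 `CCc1cccc(NC(=O)CSc2nc(Nc3ccccc3)c3ccccc3n2)c1` and compound 1 `O=C(CSc1nc(Nc2ccccc2)c2ccccc2n1)Nc1ccccc1F` share one core and differ only in the aryl group on an amide-type nitrogen. In a functional assay on PC-3 cells (Homo sapiens) for inhibition, read by MTT assay, with a stated time of 72 h (a higher number here means a weaker inhibitor, a lower number a stronger inhibitor), compound 1 gives 12400 nM, and compound 2 gives 11000 nM. Of the two numbers, compound 2 has the lower one, but the step of a 1.1-fold lower number from compound 1 to compound 2 (0.05 log units; within the scatter) lies within the scatter, so the two read as equal. Compound 3 `C=CC(=O)Nc1cccc(NC(=O)CSc2nc(Nc3ccccc3)c3ccccc3n2)c1` keeps everything in compound 2 except one change: (vinylcarbonyl)amino in place of ethyl on an aromatic carbon. Among the compounds with values here, no measured step swaps an ethyl group for a (vinylcarbonyl)amino group; the only measured step, from compound 1 to compound 2, concerns a different aryl exchange and is within the scatter. Within the data shown here, with no step bearing directly on this change, the expectation for compound 3 is a number near that of compound 2, with a wide range, giving an expected step of a 1.2-fold lower number from compound 2 to compound 3 (0.09 log units; within the scatter). Compound 3 is therefore estimated at 9000 nM, between 2500 nM and 30000 nM.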

Compound 3, half-maximal inhibitory concentration: 8740 nM
Compound 3: the middle estimate sits 1.0-fold (0.01 log units) above what was measured, and the stated range covers the measured number.
By their numbers in this assay, from the lowest: compounds 3, 2 and 1 (each within the scatter of the next).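

In this assay, the place on the aromatic ring that held ethyl also takes (vinylcarbonyl)amino, a group with more heavy atoms plus a hydrogen-bond donor and acceptor, yet the two compounds read as equal (a 1.3-fold lower number from compound 2 to compound 3 (0.10 log units; within the scatter)). Set against the 2-fluorophenyl group of compound 1, the 3-((vinylcarbonyl)amino)phenyl group also reads as equal (a 1.4-fold lower number from compound 1 to compound 3 (0.15 log units; within the scatter)), so the three aryl groups shown cannot be told apart in this assay. Nothing available here accounts for this result.

Going by these compounds, it remains open whether an amine or a carboxylic acid at this same place would give a number clearly apart from these three. A propanoylamino group, the same chain without its double bond, would show whether that double bond matters here at all.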